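Isomeric carboxylic acid side chains: notes on compound 3

This account rests on a few compounds, and the source may have more. Where it says the series, first, only, none or still open, it means among the compounds named here.

Measured in an ADME assay on microsomes from liver (Mus musculus) for metabolic stability; a higher number here means faster removal of the compound, a lower number slower removal:
- compound 1 `O=C(O)Cc1nn(Cc2cn3cc(OCC4CC4)c(Cl)cc3n2)c2ccccc2c1=O`: < 51.7 mL/min/kg
- compound 2 `CC(C)(C(=O)O)c1nn(Cc2cn3cc(OCC4CC4)c(Cl)cc3n2)c2ccccc2c1=O`: < 63.4 mL/min/kg

Both readings are limits and not numbers. Compound 2 is therefore known only through its limit of < 63.4 mL/min/kg.

The next compound is compound 3 `CCC(C(=O)O)c1nn(Cc2cn3cc(OCC4CC4)c(Cl)cc3n2)c2ccccc2c1=O`, which has the same atoms as compound 2, joined differently: 1-carboxypropyl in place of 1-carboxy-1-methylethyl on an aromatic carbon. The change lies in the chain on an aromatic carbon of a six-membered aromatic ring with 2 nitrogen.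

For the measured compounds named here, the one measured step that bears on this is a step that the two limits leave unreadable from compound 1 to compound 2, with 1-carboxy-1-methylethyl in place of carboxymethyl on that aromatic carbon. Its size cannot be read, so it offers no measured shift to carry over. No step beyond the scatter is expected in this assay, and no direction can be assigned. The expected change is a step that the limit leaves unreadable from compound 2 to compound 3. For compound 3 the estimated clearance is 45 mL/min/kg, with an expected range from 25 mL/min/kg to 65 mL/min/kg. A further reading reported only as a limit would not be unexpected.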

Compound 3, clearance: < 56.7 mL/min/kg
Compound 3: a limit, no number (the forecaster's own chance of this, stated with the estimate: 60%); the middle value is on the limit's open side.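

In this assay, for the compounds shown here, compound 1, compound 2 and compound 3 are all reported as limits and not numbers, so no step among them can be read. The compounds shown leave open whether carboxymethyl, 1-carboxy-1-methylethyl and 1-carboxypropyl on that aromatic carbon differ in clearance at all, and in which direction.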